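Sulfonyl for benzoyl on the pyridinone series: expectation

The source may hold more compounds than are shown below. What is called first, only, known or untested is meant among the compounds shown, and "the series" means these compounds.

Measured compounds:
compound 1 `O=C(c1ccccc1)c1cc(C(=O)c2ccccc2)c(=O)[nH]c1-c1ccccc1` — 5.4%
compound 2 `O=C1CCCc2[nH]c(=O)c(C(=O)c3ccccc3)cc21` — 4.3%
compound 3 `O=C1CC(c2ccccc2)Cc2[nH]c(=O)c(C(=O)c3ccccc3)cc21` — 1.7%

All three were read in an assay on isolated protein for inhibition of 3',5'-cyclic-AMP phosphodiesterase 4A (Cavia porcellus), read by cAMP accumulation, tested at 50 uM; on this read-out lower numbers stand for a weaker effect and higher numbers for a stronger effect at the one concentration tested. In this assay compound 1 gives 5.4%, compound 2 gives 4.3% and compound 3 gives 1.7%; compound 1 sits within the scatter of both compound 2 and compound 3, so the three numbers cannot be told apart, and every one of them is small.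

Compound 4 `O=C(c1ccccc1)c1cc(S(=O)(=O)c2ccccc2)c(=O)[nH]c1-c1ccccc1` is not yet measured. It differs from compound 1 in one place: phenylsulfonyl in place of benzoyl on an aromatic carbon. Within the data shown here, the only step recorded so far, a number 2.6 percentage points lower from compound 2 to compound 3 (within the scatter), concerns a phenyl in place of hydrogen on a saturated ring carbon and does not touch the benzoyl that is exchanged here, so no recorded step bears directly on the change. What the series does show is a uniformly low read-out across compounds 1, 2 and 3, with no single change moving the number beyond the scatter. The step from compound 1 to compound 4 is therefore expected to be a number 0.4 percentage points lower from compound 1 to compound 4 (within the scatter), that is, none beyond the scatter. Compound 4 is estimated at 5%, with a range from 0% to 15%.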

Compound 4, a percentage reported as inhibition, at one concentration (the size of the read-out at that concentration, not a potency): 3.5%
For compound 4 the middle estimate is 1.5 percentage points above the measured one; the measured number falls inside the stated range.
By their numbers in this assay, from the lowest: compounds 3, 4, 2 and 1 (each within the scatter of the next).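

Phenylsulfonyl in place of benzoyl on this aromatic carbon, meta to a benzoyl group and para to a phenyl group, gives a number 1.9 percentage points lower from compound 1 to compound 4 (within the scatter) in this assay. Among these compounds, this is the only recorded step at this position, and it shows that this exchange does not separate compound 4 from compound 1 on this read-out, with both numbers small. No measurement on hand accounts for the size of this step.

Open, as far as these compounds go, is whether any other group at this position would move the number in this assay beyond the scatter, for example an amine, a carboxylic acid or a longer chain in place of phenylsulfonyl. Also open, from the compounds shown here alone, is whether an exchange of the phenyl group on the core of compound 4 for one of these would do so.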